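Swapping the 3,4-dihydroxyphenyl group: notes on compound 4

The source may hold more compounds than are shown below. What is called first, only, known or untested is meant among the compounds shown, and "the series" means these compounds.

Of the compounds shown here, three with a shared core have been measured so far in a functional assay on NCI-H520 cells (Homo sapiens) for cytotoxicity; on this read-out higher numbers stand for weaker inhibition of growth and lower numbers for stronger inhibition of growth. Compound 1 `COc1ccc(C2=C(c3ccc(SC)cc3)CC3CCCN3C2=O)cc1Br` gives 700 nM there, compound 2 `COc1ccc(C2=C(c3ccc(SC)cc3)CC3CCCN3C2=O)cc1C` gives 100 nM there, and compound 3 `CSc1ccc(C2=C(c3ccc(O)c(O)c3)C(=O)N3CCCC3C2)cc1` gives 60000 nM as the highest of the three numbers, which marks the weakest inhibition of growth among them.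

Compound 4 `CSc1ccc(C2=C(c3ccc(C)cc3)C(=O)N3CCCC3C2)cc1` is not yet measured. It carries 4-methylphenyl in place of 3,4-dihydroxyphenyl on a double-bonded ring carbon next to the ring atom that bears a 4-(methylsulfanyl)phenyl group.

Two measured steps bring in the same 3,4-dihydroxyphenyl group at this place and both are large: the data show an 86-fold higher number from compound 1 to compound 3 (1.93 log units; beyond the scatter) and also a 600-fold higher number from compound 2 to compound 3 (2.78 log units; beyond the scatter) in this series. The remaining step of a 7.0-fold lower number from compound 1 to compound 2 (0.85 log units; beyond the scatter) is modest beside them. Going by the values given here, no measured compound carries 4-methylphenyl, so the comparison is indirect and the range is kept wide.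

A large step toward a lower number is therefore expected, and the estimate is a 40-fold lower number from compound 3 to compound 4 (1.60 log units; beyond the scatter) in this assay for now. For compound 4 the estimated value is 1500 nM with an expected range from 250 nM to 10000 nM at this stage.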

Compound 4, concentration for 50% growth inhibition: 900 nM
The estimate for compound 4 lay 1.7-fold (0.22 log units) above the measured number; the range from low to high includes it.
By their numbers in this assay, from the lowest: compound 2; then compounds 1 and 4 (each within the scatter of the next); then compound 3.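

In this assay the step with a 67-fold lower number from compound 3 to compound 4 (1.82 log units; beyond the scatter) shows that the high number of compound 3 belongs to the 3,4-dihydroxyphenyl group and not to every change at this double-bonded ring carbon. The all-carbon 4-methylphenyl group reads level with 3-bromo-4-methoxyphenyl, as a 1.3-fold higher number from compound 1 to compound 4 (0.11 log units; within the scatter) is printed within the scatter, so neither the bromo nor the methoxy group is needed at this place to reach that level in this assay. The place still responds to the group it carries, since a 9.0-fold higher number from compound 2 to compound 4 (0.95 log units; beyond the scatter) separates 4-methylphenyl from 4-methoxy-3-methylphenyl and keeps compound 2 with the lowest number of the four.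

No data at hand offer an explanation for any of these steps. Still open, on these data alone, is how this assay would read for a phenyl group carrying an amine or a carboxylic acid, for a longer chain in place of the methyl of 4-methylphenyl, and for a phenyl group with a single hydroxyl, which would separate the effect of one hydroxyl from that of the pair in compound 3.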